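Selenocyanate in place of the ethynyl on a propiolamide core

The source may report more compounds than this note shows. Statements on the series, on what has been measured and on what is new or still open speak of the compounds shown alone.

Compound 1 `C#CC(=O)N(Cc1ccc(OC)c(O)c1)c1cc(OC)c(OC)c(OC)c1` is the more potent of the two measured compounds: in a functional assay on KYSE-450 cells (Homo sapiens) for inhibition, read by MTT assay, with a stated time of 48 h (on this read-out lower numbers stand for stronger inhibition and higher numbers for weaker inhibition), compound 1 gives 570 nM, the lowest of the two numbers, and its nearest neighbour, compound 2 `COc1ccc(N(Cc2cc(OC)c(OC)c(OC)c2)C(=O)CN=[N+]=[N-])cc1O`, stands a long way above it, beyond the usual scatter, since in this assay compound 2 gives 26100 nM. For the measured compounds named here, compound 2 differs from compound 1 in more than one place, so no single step between them is defined, and only the two values themselves are known.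

Compound 3 `COc1ccc(CN(C(=O)C[Se]C#N)c2cc(OC)c(OC)c(OC)c2)cc1O` has not yet been tested. It differs from compound 1 in one place: a group of 4 heavy atoms (2 carbon, 1 nitrogen, 1 selenium; no ring) in place of a group of 2 heavy atoms (2 carbon; no ring), on a carbonyl carbon. Going by the values given here, no measured pair shows what this exchange on the carbonyl carbon does, so the expectation rests on the two numbers alone. Compound 3 is expected to lose some potency relative to compound 1, with the step of a 4.4-fold higher number from compound 1 to compound 3 (0.64 log units; beyond the scatter) estimated to go beyond the scatter but to stay well short of the gap that separates compound 1 from compound 2. For compound 3 the estimate in this assay is 2500 nM, with a plausible range from 400 nM to 15000 nM.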

Compound 3, half-maximal inhibitory concentration: 280 nM
Beside the measured number, compound 3's estimate is 8.9-fold (0.95 log units) above it; measured number below the stated range.
By their numbers in this assay, from the lowest: compound 3; then compound 1; then compound 2.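

For the compounds shown here, the exchange on the carbonyl carbon gives a 2.0-fold lower number from compound 1 to compound 3 (0.31 log units; beyond the scatter) in this assay, a modest gain, and this is the first single-place comparison available at this position. It shows that the ethynyl group is not needed for potency on the core of compound 1, since the larger selenocyanate group, which also holds a triple bond outside aromatic rings but adds a hydrogen-bond acceptor, does at least as well there. Nothing available explains why the number falls, and this single pair cannot show which part of the entering group matters.

What the compounds shown leave open is whether selenium has any part in this gain, since a thiocyanate or a plain cyanomethyl group on the same carbonyl carbon would tell the selenium apart from the nitrile. From the compounds shown here alone, it also remains open how far this position tolerates other kinds of group, such as an amine, a carboxylic acid or a longer chain ending in the nitrile, and whether the gain would hold on any other cell line.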